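Working notes on a small series and one untested analogue

The source may report more compounds than this note shows. Statements on the series, on what has been measured and on what is new or still open speak of the compounds shown alone.

Measured so far:
compound 1, `COc1ccc(/C=C/C(=O)NC(=O)c2ccccc2)cc1O`, gives 7.02% in a functional assay, with a stated time of 30 min, tested at 1 mM; a lower number here means less inhibition, a higher number more inhibition at the concentration tested (going by the name of the read-out).
compound 2, `COc1ccc(/C=C/C(=O)NC(=O)c2ccccc2)cc1`, gives 5.61% in this assay.
compound 3, `O=C(/C=C/c1ccc(O)cc1)NC(=O)c1ccccc1`, gives 4.89% in this assay.

Among the measured compounds shown here, all three numbers sit close together, and no compound can be called stronger or weaker than another on these data. The change from compound 2 to compound 1 is hydroxy in place of hydrogen on an aromatic carbon; its effect is a number 1.4 percentage points higher from compound 2 to compound 1 (within the scatter). The cores of compound 2 and compound 3 differ by hydrogen in place of methyl on an oxygen on an aromatic ring; that step reads a number 0.7 percentage points lower from compound 2 to compound 3 (within the scatter). Compound 3 has the lowest number of the three, but its distances to compound 2 and compound 1 are both within the scatter.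

Compound 4, `O=C(/C=C/c1ccc(O)c(O)c1)NC(=O)c1ccccc1`, has not been measured. It differs from compound 3 by hydroxy in place of hydrogen on an aromatic carbon. This is the same kind of change as from compound 2 to compound 1, but the place is not identical: in compound 4 the entering hydroxy is ortho to a hydroxy group, whereas in compound 1 it is ortho to a methoxy group. For the measured compounds named here, the one measured instance of this change moved the read-out by a number 1.4 percentage points higher from compound 2 to compound 1 (within the scatter), within the scatter, so a similarly small step is expected here: compound 4 is estimated at a number 1.6 percentage points higher from compound 3 to compound 4 (within the scatter) relative to compound 3. Going by the values given here, on that basis compound 4 is expected to give about 6.5% in this assay, with a plausible range from 0% to 15%, since the only analogous step, from compound 2 to compound 1, stayed within the scatter.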

Compound 4, a percentage reported as inhibition, at one concentration (the size of the read-out at that concentration, not a potency): 82.9%
Beside the measured number, compound 4's estimate is 76.4 percentage points below it; measured number outside the range, above it.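

In this assay, hydroxy in place of hydrogen on an aromatic carbon reads a number 78 percentage points higher from compound 3 to compound 4 (beyond the scatter), so this change does not carry over in size from the core of compound 2 to the core of compound 3: the same change on two cores in this assay, a number 1.4 percentage points higher (within the scatter) from compound 2 to compound 1 and a number 78 percentage points higher (beyond the scatter) from compound 3 to compound 4, 76.6 percentage points apart, beyond the scatter of two such steps

Hydrogen in place of methyl on an oxygen on an aromatic ring reads a number 75.9 percentage points higher from compound 1 to compound 4 (beyond the scatter), and it too differs between the two cores: the same change on two cores in this assay, a number 0.7 percentage points lower (within the scatter) from compound 2 to compound 3 and a number 75.9 percentage points higher (beyond the scatter) from compound 1 to compound 4, 76.6 percentage points apart, beyond the scatter of two such steps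

Both large steps end at compound 4, so in this series neither change can be treated as a fixed increment, and its size depends on what the rest of the compound carries; this rests on a single high reading at one concentration, however, and shows neither why the steps differ nor that the same would hold on any other core.

As far as these compounds go, it remains open whether the high reading requires a hydroxy group ortho to a hydroxy group specifically, or whether an amine or a carboxylic acid at the place of the entering hydroxy would also give it. From the compounds shown here alone, it is equally open whether the reading of compound 4 would persist with a chlorine or a methyl group on the other aromatic ring of the shared core.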